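The compounds below may be only part of what the source reports. "The series", "measured", "known", "first", "only" and "open" are said of these compounds alone.

In a functional assay on MCF7 cells (Homo sapiens) for cytotoxicity, read by sulforhodamine B assay, with a stated time of 48 h (a higher number here means a weaker inhibitor, a lower number a stronger inhibitor), compound 1 (`N#Cc1c(-c2ccc(Cl)cc2)cc(-c2ccc(Cl)cc2)n(CC(O)CCl)c1=O`) gives 4.6 ug/mL and compound 2 (`CCn1c(-c2ccc(Cl)cc2)cc(-c2ccc(Cl)cc2)c(C#N)c1=O`) gives 19.7 ug/mL, so compound 2 holds the higher number of the two. The next entry is compound 3 (`C#CCn1c(-c2ccc(Cl)cc2)cc(-c2ccc(Cl)cc2)c(C#N)c1=O`), not yet measured, which keeps the shared core and differs from compound 2 in one group: ethynyl in place of methyl on a saturated chain carbon bound to an aromatic nitrogen. This is ethynyl in place of methyl on a saturated chain carbon bound to an aromatic nitrogen, which can also be read as ethyl to propargyl. Within the data shown here, only one measured step bears on that place: a 4.3-fold higher number from compound 1 to compound 2 (0.63 log units; beyond the scatter), modest and beyond the scatter. Among the measured compounds shown here, it shows that this assay responds to a change there, but the group involved is 2-chloro-1-hydroxyethyl, and no measured compound carries ethynyl. The evidence is therefore thin, and only a weak lean away from the methyl compound is justified. The expected step is a 1.6-fold lower number from compound 2 to compound 3 (0.22 log units; within the scatter), a small move toward a lower number that may stay within the scatter. For compound 3 the estimated value is 12 ug/mL, with an expected range from 4 ug/mL to 35 ug/mL.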

Compound 3, half-maximal inhibitory concentration: 16.7 ug/mL
Compound 3: the middle estimate sits 1.4-fold (0.14 log units) below what was measured, within the range that was stated.
By their numbers in this assay, from the lowest: compound 1; then compounds 3 and 2 (each within the scatter of the next).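

In this assay, the change from ethyl to propargyl on a saturated chain carbon bound to an aromatic nitrogen gives a 1.2-fold lower number from compound 2 to compound 3 (0.07 log units; within the scatter), so compound 2 and compound 3 cannot be told apart and the added triple bond has no readable effect here. Ethynyl in place of 2-chloro-1-hydroxyethyl at the same place gives a 3.6-fold higher number from compound 1 to compound 3 (0.56 log units; beyond the scatter), and with a 4.3-fold higher number from compound 1 to compound 2 (0.63 log units; beyond the scatter) this makes compound 1 the one compound of the three set apart, so the response at this position now rests on two separate comparisons with compound 1 rather than one. No measurement on these compounds bears on the reason for that separation.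

The compounds shown leave open whether the hydroxyl, the chlorine or both within the 2-chloro-1-hydroxyethyl group of compound 1 carry the difference, since no chain here holds one of them without the other. Also open, as far as these compounds go, is how this assay would respond to an amine, a carboxylic acid or a longer chain at this place on the shared core.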